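This account rests on a few compounds, and the source may have more. Where it says the series, first, only, none or still open, it means among the compounds named here.

Compound 1: `O=c1ccc(-c2ccc3cn[nH]c3c2)cn1Cc1ccccc1C(F)(F)F`, 133 nM in an assay for inhibition of MAP kinase-interacting serine/threonine-protein kinase 1 (Homo sapiens), read by luminescence and ADP-Glo, with a stated time of 2 h; a lower number here means a stronger inhibitor, a higher number a weaker inhibitor.
Compound 2: `Nc1cccc(Cn2cc(-c3ccc4cn[nH]c4c3)ccc2=O)c1`, 287 nM.
Compound 3: `O=c1ccc(-c2ccc3cn[nH]c3c2)cn1Cc1ccccc1Cl`, 80 nM.

Compound 3 gives the lowest of the three numbers, but a 1.7-fold lower number from compound 1 to compound 3 (0.22 log units; within the scatter) lies within the scatter, so compound 3 and compound 1 cannot be told apart; only a 3.6-fold lower number from compound 2 to compound 3 (0.55 log units; beyond the scatter) is beyond the scatter. Compound 4 is `O=c1ccc(-c2ccc3cn[nH]c3c2)cn1Cc1ccc(Cl)c(Cl)c1`, which differs from compound 3 by 3,4-dichlorophenyl in place of 2-chlorophenyl on a saturated chain carbon bound to an aromatic nitrogen. Both measured steps bear on it, since each swaps groups on this same phenyl ring: one step was within the scatter and the other modest. A step of similar small size, in either direction, is therefore expected in this assay, most likely none beyond the scatter. Compound 4 is estimated at 90 nM, within 40 nM to 220 nM, meaning an expected step of a 1.1-fold higher number from compound 3 to compound 4 (0.05 log units; within the scatter).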

Compound 4, half-maximal inhibitory concentration: 62 nM
Beside the measured number, compound 4's estimate is 1.5-fold (0.16 log units) above it, within the range that was stated.
By their numbers in this assay, from the lowest: compounds 4, 3 and 1 (each within the scatter of the next, the first and the last beyond it); then compound 2.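

In this assay, 3,4-dichlorophenyl in place of 2-chlorophenyl gives a 1.3-fold lower number from compound 3 to compound 4 (0.11 log units; within the scatter) and so shows that, on a saturated chain carbon bound to an aromatic nitrogen, a ring with two chlorines serves as well as a ring with one. Set against 3-aminophenyl, the same group gives a 4.6-fold lower number from compound 2 to compound 4 (0.67 log units; beyond the scatter) and repeats the gap already seen with compound 3. No measurement here explains either step. Still open, as far as these compounds go, is how a carboxylic acid or a methoxy group on this ring would fare, and whether a longer chain would keep these numbers.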